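Carbonyl substituent swap in the nitrile series: compound 3 to compound 4

The compounds below may be only part of what the source reports. "The series", "measured", "known", "first", "only" and "open" are said of these compounds alone.

Values in a functional assay on A20 cells (Mus musculus) for inhibition, with stated times of 1 h, 16 h and 24 h; a lower number here means a stronger inhibitor, a higher number a weaker inhibitor:
- compound 1 `N#CCNC(=O)[C@@H]1C[C@@H](S(=O)(=O)c2ccccc2Cl)C[C@H]1C(=O)N1CCOCC1`: 3 nM
- compound 2 `N#CCNC(=O)[C@@H]1C[C@@H](S(=O)(=O)c2ccccc2C(F)(F)F)C[C@H]1C(=O)N1CCOCC1`: 2 nM
- compound 3 `N#CC1(NC(=O)[C@@H]2C[C@@H](S(=O)(=O)c3ccccc3)C[C@H]2C(=O)N2CC3CCC(C2)O3)CC1`: 16 nM
- compound 4 `N#CC1(NC(=O)[C@@H]2C[C@@H](S(=O)(=O)c3ccccc3)C[C@H]2C(=O)N2CCNCC2)CC1`: not yet measured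

Compound 3, at 16 nM, has the highest number of the three. The change to compound 4 is a group of 6 heavy atoms (4 carbon, 2 nitrogen; one six-membered non-aromatic ring with 2 hetero atoms) in place of a group of 8 heavy atoms (6 carbon, 1 nitrogen, 1 oxygen; one five-membered non-aromatic ring with 1 hetero atom, one six-membered non-aromatic ring with 2 hetero atoms), on a carbonyl carbon, with piperazin-1-yl entering on a carbonyl carbon. Among the compounds with values here, the only measured step, a 1.5-fold lower number from compound 1 to compound 2 (0.18 log units; within the scatter), places trifluoromethyl in place of chloro on an aromatic carbon and stays within the scatter. Within the data shown here, no measured step covers a change on the carbonyl carbon, so no direction can be read from the data. The expected change is a 1.3-fold higher number from compound 3 to compound 4 (0.10 log units; within the scatter), none beyond the scatter, with wide uncertainty. For compound 4 the estimate is 20 nM, with an expected range of 6 nM to 70 nM.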

Compound 4, half-maximal inhibitory concentration: 1340 nM
The estimate for compound 4 lay 67-fold (1.83 log units) below the measured number; the measured number lies above the stated range.
By their numbers in this assay, from the lowest: compounds 2 and 1 (each within the scatter of the next); then compound 3; then compound 4.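

In this assay, within the data shown here, the carbonyl carbon whose other neighbour is a saturated ring carbon proves a highly sensitive place: piperazin-1-yl in place of the group of 8 heavy atoms gives an 84-fold higher number from compound 3 to compound 4 (1.92 log units; beyond the scatter) and so far exceeds the only other measured step, which stays within the scatter. The entering group has 1 hydrogen-bond donor and the leaving group has none, but nothing available links that difference or any other to the size of this step. As far as these compounds go, it remains open whether the large rise is specific to piperazin-1-yl. A 4-methylpiperazin-1-yl or a piperidin-1-yl group on the same carbonyl carbon would show whether the number stays near that of compound 3 or that of compound 4.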